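The source may report more compounds than this note shows. Statements on the series, on what has been measured and on what is new or still open speak of the compounds shown alone.

Measured so far:
- compound 1, `Cc1oc(-c2ccc(Cl)cc2)nc1CN1CCC(C(=O)NCCCN2C[C@H](C)C[C@H](C)C2)CC1`: > 0.5 h
- compound 2, `Cc1ccccc1-c1nc(CN2CCC(C(=O)NCCCN3CCCCC3)CC2)c(C)o1`: > 0.5 h

Both entries come from an ADME assay on microsomes from liver (Rattus norvegicus) for metabolic stability, read by LC-MS, using NADPH, at 37 degrees C; a higher number here means that the compound lasts longer, a lower number that the compound disappears faster. For compound 1 the figure > 0.5 h is a limit of this assay and not a number. For compound 2 the figure > 0.5 h is likewise a limit of this assay. Among the compounds with values here, compound 1 therefore stands at the limit of > 0.5 h in this assay, at which 2 of the 2 values shown sit, and no number separates it from compound 2; the two results show only that neither compound disappeared within the window of this assay.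

The next compound, compound 3, `Cc1cccc(-c2nc(CN3CCC(C(=O)NCCCN4C[C@H](C)C[C@H](C)C4)CC3)c(C)o2)c1`, is not yet measured in this assay. It differs from compound 1 by 3-methylphenyl in place of 4-chlorophenyl on an aromatic carbon.

Within the data shown here, no step between measured compounds exists in this assay, so the size of the change from compound 1 to compound 3 cannot be read from a precedent. Since compound 1 gives > 0.5 h, the working expectation is that compound 3 also sits at or beyond the limit, with no shift beyond the usual scatter. The expected step from compound 1 to compound 3 is a step that the limit leaves unreadable from compound 1 to compound 3. Compound 3 is estimated at 0.8 h, in a range from 0.4 h to 2 h, most likely reported as a limit.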

Compound 3, half-life: > 0.5 h
Compound 3 gave a limit, no number; the forecaster's own chance of this, stated with the estimate: 70%; the middle value does not contradict the limit.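

No step can be read between compound 1 and compound 3, since both results are limits and not numbers: the limit of > 0.5 h in this assay, at which 3 of the 3 values shown sit.

The compounds shown leave open how long any of them lasts beyond that limit, and whether 3-methylphenyl in place of 4-chlorophenyl on an aromatic carbon changes the half-life at all.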